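The compounds below may be only part of what the source reports. "The series", "measured", "known", "first", "only" and "open" are said of these compounds alone.

Among the measured compounds shown here, in a functional assay on HOS cells (Homo sapiens) for antiproliferative activity, read by sulforhodamine B assay (a higher number here means a weaker inhibitor of growth, a lower number a stronger inhibitor of growth), compound 1 (`CCC[C@@H]1O[C@H](COCc2ccccc2)[C@@H](OCc2ccccc2)[C@H](OCc2ccccc2)[C@H]1O`) gives 38600 nM and compound 2 (`OCC[C@@H]1O[C@H](COCc2ccccc2)[C@@H](OCc2ccccc2)[C@H](OCc2ccccc2)[C@H]1O`) gives 39700 nM so compound 2 stands level, within the scatter, with the only other compound measured. Compound 3 (`O[C@@H]1[C@@H](OCc2ccccc2)[C@H](OCc2ccccc2)[C@@H](COCc2ccccc2)O[C@H]1CC1CCCCC1`) carries cyclohexyl in place of hydroxymethyl on a saturated chain carbon bound to a saturated ring carbon. For the measured compounds named here, the one measured step on this chain (a 1.0-fold higher number from compound 1 to compound 2 (0.01 log units; within the scatter)) stayed within the scatter, but it exchanged only methyl for hydroxy, so it says little about a change of this size. With so little to go on, a modest step towards a lower number is expected in this assay and a result within the scatter remains possible. The estimate amounts to an expected 1.8-fold lower number from compound 2 to compound 3 (0.26 log units; within the scatter) in this test. For compound 3 the estimated value is 22000 nM with an expected range from 9000 nM to 50000 nM in this test.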

Compound 3, concentration for 50% growth inhibition: 4400 nM
Compound 3: middle estimate off by 5.0-fold (0.70 log units), on the high side; the measured number lies below the stated range.
By their numbers in this assay, from the lowest: compound 3; then compounds 1 and 2 (each within the scatter of the next).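

In this assay, the chain carbon bound to a saturated ring carbon proves responsive to what it carries, which the exchange of methyl for hydroxy had not revealed. Cyclohexyl in place of hydroxymethyl gives a 9.0-fold lower number from compound 2 to compound 3 (0.96 log units; beyond the scatter), and cyclohexyl in place of ethyl gives an 8.8-fold lower number from compound 1 to compound 3 (0.94 log units; beyond the scatter). Both steps lie beyond the scatter and start from compounds that stand level, so the same outcome is seen whether the group replaced ends in hydroxy or in methyl.

On these data alone, whether it is the cyclohexyl ring itself that counts, or whether a phenyl ring or a straight hexyl chain on this carbon would give a similar number, remains open. Nothing available here accounts for the size of these steps.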